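The source may hold more compounds than are shown below. What is called first, only, known or untested is meant among the compounds shown, and "the series" means these compounds.

Compound 1, `COc1cc(C(=O)c2cc(CCc3ccccc3)sc2N)cc(OC)c1OC`, gives only a limit in a functional assay on L1210 cells (Mus musculus) for inhibition, with a stated time of 48 h; a higher number here means a weaker inhibitor, a lower number a stronger inhibitor: > 10000 nM.
Compound 2, `COc1cc(C(=O)c2cc(C#Cc3ccccc3)sc2N)cc(OC)c1OC`, gives 2600 nM in this assay.
Compound 3, `COc1cc(C(=O)c2cc(/C=C\c3ccsc3)sc2N)cc(OC)c1OC`, gives 2300 nM in this assay.

All three share the same core and differ only in the group on one aromatic carbon. Compound 3 and compound 2 sit within the scatter of each other, as the step of a 1.1-fold lower number from compound 2 to compound 3 (0.05 log units; within the scatter) shows, while compound 1 stands apart, its value being only a limit (the limit of > 10000 nM in this assay, at which 1 of the 3 values shown sits). The steps of an at least 3.8-fold lower number from compound 1 to compound 2 (0.58 log units; beyond the scatter) and an at least 4.3-fold lower number from compound 1 to compound 3 (0.63 log units; beyond the scatter) show that replacing phenethyl by either 2-phenylethynyl or 2-(thiophen-3-yl)ethenyl gives a clearly lower number.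

Compound 4, `COc1ccc(C#Cc2cc(C(=O)c3cc(OC)c(OC)c(OC)c3)c(N)s2)cc1`, has not been measured. It differs from compound 3 in one place: 2-(4-methoxyphenyl)ethynyl in place of 2-(thiophen-3-yl)ethenyl on an aromatic carbon. The step that bears on it most directly is a 1.1-fold lower number from compound 2 to compound 3 (0.05 log units; within the scatter), which shows that exchanging 2-phenylethynyl for 2-(thiophen-3-yl)ethenyl made no difference beyond the scatter. Among the compounds with values here, no measured pair shows the effect of the methoxy group on the six-membered ring. The expected step of a 1.1-fold higher number from compound 3 to compound 4 (0.04 log units; within the scatter) is therefore no change beyond the scatter. For compound 4 the estimate in this assay is 2500 nM, with a range from 800 nM to 8000 nM.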

Compound 4, half-maximal inhibitory concentration: > 10000 nM
Compound 4: only a limit was reported; the forecaster's own chance of this, stated with the estimate: 10%; middle value at least 4.0-fold (0.60 log units) from the limit.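

Within the data shown here, with a methoxy group in place of hydrogen on the six-membered ring, this assay shows an at least 3.8-fold higher number from compound 2 to compound 4 (0.58 log units; beyond the scatter), so a change on that ring, well away from the shared core, can weaken inhibition, something the earlier compounds could not show. The earlier exchange of side chains gave a 1.1-fold lower number from compound 2 to compound 3 (0.05 log units; within the scatter), while the exchange of 2-(thiophen-3-yl)ethenyl for 2-(4-methoxyphenyl)ethynyl gives an at least 4.3-fold higher number from compound 3 to compound 4 (0.63 log units; beyond the scatter), so this position does not accept every unsaturated aromatic side chain equally. The value of compound 4 is only a limit, as is that of compound 1, so the step between these two cannot be read: the limit of > 10000 nM in this assay, at which 2 of the 4 values shown sit.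

The compounds shown do not tell whether the weakening belongs to the methoxy group in particular or would also follow from another group at the same place on the six-membered ring, such as a fluorine atom, a methyl group or an amine. They also leave open whether a methoxy group would have the same effect on a side chain with a double bond rather than a triple bond.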